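The source may hold more compounds than are shown below. What is called first, only, known or untested is meant among the compounds shown, and "the series" means these compounds.

Measured so far:
compound 1 `Cc1cc(C)c(S(=O)(=O)N2CCC(c3ccccc3)CC2)c(C)c1`: > 5000 nM
compound 2 `CC1CCN(C2CCN(S(=O)(=O)c3cccc(-c4ccccc4F)c3)CC2)CC1`: 10 nM

In a functional assay on DLD-1 cells (Homo sapiens) for antiproliferative activity, read by CellTiter-Glo, with a stated time of 72 h (a lower number here means a stronger inhibitor, a higher number a weaker inhibitor), compound 1 reaches only a limit, standing at the limit of > 5000 nM in this assay, at which 1 of the 2 values shown sits. Going by the values given here, compound 2 gives 10 nM in this assay, the only real number in the set so far.

Compound 3 `CC1CCN(C2CCN(S(=O)(=O)c3cccc(Br)c3)CC2)CC1` differs from compound 2 by bromo in place of 2-fluorophenyl on an aromatic carbon. Among the compounds with values here, no measured step covers a change of this kind, so its size is uncertain. A loss of potency in this assay is expected, with the step of a 12-fold higher number from compound 2 to compound 3 (1.08 log units; beyond the scatter) estimated as moderate and clearly beyond the scatter. For compound 3 an estimated 120 nM in this assay is expected, within 25 nM to 800 nM.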

Compound 3, half-maximal inhibitory concentration: 3.2 nM
For compound 3 the middle estimate is 38-fold (1.57 log units) above the measured one, outside the stated range (below it).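

In this assay, putting bromo in place of 2-fluorophenyl on this aromatic carbon, meta to a large group, gives a 3.1-fold lower number from compound 2 to compound 3 (0.49 log units; beyond the scatter) and is a modest gain. The second aromatic ring is therefore not required at this position in the shared core, and a single bromine atom suffices for the potency seen here. Nothing measured in the data at hand accounts for the step.

On these data alone, whether this potency is specific to bromo remains open. Chloro, methyl, nitrile or an amine on the same carbon would show how far the position tolerates other small groups.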